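The source may hold more compounds than are shown below. What is called first, only, known or untested is meant among the compounds shown, and "the series" means these compounds.

Working notes on the series around compound 2 `CCc1nn(C)c(CO/N=C/c2c(C)nn(C)c2Oc2cccc(Cl)c2)c1Cl`. Compound 1 `CCc1nn(C)c(CO/N=C/c2c(C)nn(C)c2Oc2ccc(F)cc2)c1Cl` carries the shared core with a 4-fluorophenyl on the ring oxygen. In a functional assay on SMMC-7721 cells (Homo sapiens) for inhibition, read by MTT assay, with a stated time of 72 h, tested at 25 uM (a higher number here means more inhibition at the concentration tested (going by the name of the read-out), a lower number less inhibition), compound 1 gives only a limit, < 80%, not a number. In this assay compound 2 likewise gives only a limit, < 80%. The step between them, a step that the two limits leave unreadable from compound 1 to compound 2, cannot be read, since both ends are limits. Within the data shown here, compound 3 `Cc1nn(C)c(Oc2ccc(OC(F)(F)F)cc2)c1/C=N\OCc1c(Cl)c(-c2ccc(F)cc2)nn1C`, the one member of the set with a measured number, gives 80% in this assay, which sits exactly at the edge where the other two values stop; this is the situation summed up by the limit of < 80% in this assay, at which 2 of the 3 values shown sit.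

The next compound, compound 4 `CCc1nn(C)c(CO/N=C/c2c(C)nn(C)c2Oc2cccc(C)c2)c1Cl`, differs from compound 2 in one place: methyl in place of chloro on an aromatic carbon. Among the measured compounds shown here, no measured step in the set bears on this change, and the only step in the set is itself unreadable. The expectation for compound 4 in this assay therefore rests on compound 2 alone, whose value < 80% is a limit, so the expected step that the limit leaves unreadable from compound 2 to compound 4 is taken to be none beyond the scatter. Compound 4 is accordingly estimated at 50% in this assay, with a range from 10% to 80%, and most likely it too will be reported only as a limit.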

Compound 4, a percentage reported as inhibition, at one concentration (the size of the read-out at that concentration, not a potency): < 80%
Compound 4 was reported as a limit; the forecaster's own chance of this, stated with the estimate: 70%; the middle value is on the limit's open side.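

In this assay compound 4 gives only a limit, < 80%. No new step can be read from compound 4 to compound 2 or compound 1, because all three values are limits: the limit of < 80% in this assay, at which 3 of the 4 values shown sit.

The compounds shown leave open how much inhibition compound 1, compound 2 and compound 4 actually give, and whether methyl in place of chloro changes it.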